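Methoxycarbonyl in Place of Ethyl: Compound 2 to Compound 3

The source may hold more compounds than are shown below. What is called first, only, known or untested is meant among the compounds shown, and "the series" means these compounds.

Measured so far:
compound 1, `CC(C)(C)OC(=O)N1CCC(CCCNc2ccc3c(c2)C(=O)CO3)CC1`: 116%
compound 2, `CCc1cnc(N2CCC(CCCNc3ccc4c(c3)OCC4=O)CC2)nc1`: 98%

In a functional assay on CHO-K1 cells for agonist activity at Glucose-dependent insulinotropic receptor (Mus musculus), read by HTRF and cAMP accumulation, with a stated time of 30 min (a lower number here means a smaller maximal response, a higher number a larger maximal response), compound 1 reaches 116%, and compound 2 reaches 98%. Compound 2 thus stands lowest of the two numbers; its nearest neighbour is compound 1, whose response is higher by a margin beyond the scatter. Compound 3 `COC(=O)c1cnc(N2CCC(CCCNc3ccc4c(c3)OCC4=O)CC2)nc1` is the next compound along the same route. It differs from compound 2 as follows: methoxycarbonyl in place of ethyl on an aromatic carbon. For the measured compounds named here, no step between two measured compounds mirrors this change, so the expectation rests on the two values alone, both of which sit near the reference. Compound 3 is therefore expected to give a response close to that of compound 2, with the step of a number 3 percentage points lower from compound 2 to compound 3 (within the scatter) expected to stay within the scatter. The estimate for compound 3 in this assay is 95%, ranging from 70% to 115%.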

Compound 3, largest response reached (Emax), in percent of the reference or control that the assay uses: 67%
Estimate against measurement, compound 3: 28 percentage points above; measured number below the stated range.
By their numbers in this assay, from the lowest: compound 3; then compound 2; then compound 1.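

Moving from 5-ethylpyrimidin-2-yl to 5-(methoxycarbonyl)pyrimidin-2-yl gives the only single-place step available here, and in this assay it brings a number 31 percentage points lower from compound 2 to compound 3 (beyond the scatter). The maximal response therefore depends on the group at this aromatic carbon, which the two earlier values could not show, since those compounds do not form such a step. The data offer no measured property that bears on the reason for this drop.

On these data alone, it remains open whether the response follows the whole ester or only its carbonyl, which a carboxylic acid, a primary amide or a nitrile on the same aromatic carbon would help to separate. It is equally unsettled how a methyl group or a longer chain such as propyl would compare with ethyl at this position.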